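Dibromo to dimethyl on the hydroxyphenyl arm

This account rests on a few compounds, and the source may have more. Where it says the series, first, only, none or still open, it means among the compounds named here.

Three measured compounds share one core and differ only in the aryl group held on a carbon with a double bond to nitrogen. In a functional assay on A549 cells (Homo sapiens) for cytotoxicity, read by MTT assay, with a stated time of 72 h (on this read-out lower numbers stand for stronger inhibition and higher numbers for weaker inhibition), compound 1 `CN(C)CCn1cnnc1-c1cc(Oc2ccc(NC(=O)N/N=C/c3ccccc3O[N+](=O)[O-])cc2F)ccn1` gives 1200 nM. Compound 2 `CN(C)CCn1cnnc1-c1cc(Oc2ccc(NC(=O)N/N=C/c3ccc(F)cc3)cc2F)ccn1` gives 1790 nM in this assay, and a 1.5-fold higher number from compound 1 to compound 2 (0.17 log units; within the scatter). Compound 3 `CN(C)CCn1cnnc1-c1cc(Oc2ccc(NC(=O)N/N=C/c3cc(Br)c(O)c(Br)c3)cc2F)ccn1` stands at > 100000 nM, which is a limit of this assay rather than a number, as shown by the limit of > 100000 nM in this assay, at which 1 of the 3 values shown sits. The steps toward compound 3 are both large: an at least 83-fold higher number from compound 1 to compound 3 (1.92 log units; beyond the scatter), and an at least 55-fold higher number from compound 2 to compound 3 (1.74 log units; beyond the scatter).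

Compound 4 `Cc1cc(/C=N/NC(=O)Nc2ccc(Oc3ccnc(-c4nncn4CCN(C)C)c3)c(F)c2)cc(C)c1O` differs from compound 3 in one place: 4-hydroxy-3,5-dimethylphenyl in place of 3,5-dibromo-4-hydroxyphenyl on a carbon with a double bond to nitrogen. Going by the values given here, no measured step tests this particular swap, so the outlook rests on compound 3 sitting at the limit while compounds 1 and 2 give measurable numbers. Compound 4 is therefore expected to give an estimated 20000 nM, with a range from 2500 nM to 100000 nM. As an expectation, that would amount to an at least 5.0-fold lower number from compound 3 to compound 4 (0.69 log units; beyond the scatter).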

Compound 4, half-maximal inhibitory concentration: 1640 nM
Beside the measured number, compound 4's estimate is 12-fold (1.09 log units) above it, outside the stated range (below it).
By their numbers in this assay, from the lowest: compounds 1, 4 and 2 (each within the scatter of the next). At a limit, above all of these: compound 3.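

In this assay, keeping the hydroxyl and exchanging only the two bromines for two methyl groups gives an at least 60-fold lower number from compound 3 to compound 4 (1.78 log units; beyond the scatter), so a hydroxyphenyl group at this place does not by itself rule out a measurable number. The new value also falls in with the other two: a 1.1-fold lower number from compound 2 to compound 4 (0.04 log units; within the scatter), and a 1.4-fold higher number from compound 1 to compound 4 (0.14 log units; within the scatter), so three quite different aryl groups on this carbon read alike. Compound 3 remains a limit, not a number: the limit of > 100000 nM in this assay, at which 1 of the 4 values shown sits.

The compounds shown leave open whether chlorine atoms or methoxy groups in place of the two methyl groups would read like compound 4 or like compound 3. They also leave open whether the hydroxyl of compound 4 matters at all, which an amino group in its place would begin to test.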